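A few compounds are considered here, and "the series" means these few. Any claim that something is new, unique, unknown or untested is made for them only; others in the source may bear on it.

Measured so far:
compound 1 `CNC(=O)c1cc(Oc2ccc3nc(NC(=O)Nc4ccc(Cl)cc4)sc3c2)ccn1` — 85.2%
compound 2 `CNC(=O)c1cc(Oc2ccc3nc(NC(=O)Nc4ccc(C5CCN(C(C)C)CC5)cc4)sc3c2)ccn1` — 95.5%

For the measured compounds named here, in a functional assay on HCT-116 cells (Homo sapiens) for inhibition, read by MTT assay, with a stated time of 2 days, tested at 100 uM (a lower number here means less inhibition of growth, a higher number more inhibition of growth at the concentration tested), compound 2 holds the highest of the two numbers so far; its nearest neighbour is compound 1, separated by a step of a number 10.3 percentage points higher from compound 1 to compound 2 (beyond the scatter). Compound 3 `CNC(=O)c1cc(Oc2ccc3nc(NC(=O)Nc4ccc(F)cc4)sc3c2)ccn1` differs from compound 2 in one place: fluoro in place of 1-isopropylpiperidin-4-yl on an aromatic carbon.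

Going by the values given here, only one measured step bears on this change, the one from compound 1 to compound 2, a number 10.3 percentage points higher from compound 1 to compound 2 (beyond the scatter), in which the same 1-isopropylpiperidin-4-yl group entered in place of a halogen. The move to compound 3 runs that exchange backwards, with fluoro rather than chloro as the halogen, so a decrease of roughly that size, back toward the value of compound 1, is expected. Among the compounds with values here, no measured pair separates fluoro from chloro at this position, so the fluoro analogue is taken to sit near compound 1, with wider uncertainty. The expected step is a number 13.5 percentage points lower from compound 2 to compound 3 (beyond the scatter). For compound 3 the estimate is 82%, within 65% to 95%.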

Compound 3, percent growth inhibition at one concentration: 83.8%
Estimate against measurement, compound 3: 1.8 percentage points below; the measured number falls inside the stated range.
By their numbers in this assay, from the lowest: compounds 3 and 1 (each within the scatter of the next); then compound 2.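

In this assay, fluoro in place of chloro on this aromatic carbon gives no separable difference (a number 1.4 percentage points lower from compound 1 to compound 3 (within the scatter)), so these two halogens cannot be told apart at this position. Fluoro in place of 1-isopropylpiperidin-4-yl gives a modest step beyond the scatter (a number 11.7 percentage points lower from compound 2 to compound 3 (beyond the scatter)), so the gap between the 1-isopropylpiperidin-4-yl group and a halogen now holds for both chloro and fluoro. No measurement at hand accounts for this gap.

From the compounds shown here alone, it remains open whether the gap depends on the piperidine ring, its nitrogen or the isopropyl group, which a piperidine without the isopropyl group, a cyclohexyl ring or a morpholine at this position would help separate. Going by these compounds, all three readings come from one concentration, so how the compounds compare across a range of concentrations also remains open.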